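Changing the group on a sulfonyl sulfur

This account rests on a few compounds, and the source may have more. Where it says the series, first, only, none or still open, it means among the compounds named here.

Of the compounds shown here, three sharing one core have been tested in a functional assay on K562 cells (Homo sapiens) for inhibition, read by trypan blue exclusion, with a stated time of 72 h; a lower number here means a stronger inhibitor, a higher number a weaker inhibitor. Compound 1 `Cn1c(=O)c(S(=O)(=O)Cc2ccc(F)cc2)cc2cnc(Nc3ccc4[nH]ccc4c3)nc21` gives 30000 nM, compound 2 `Cn1c(=O)c(S(=O)(=O)c2ccc(Cl)cc2)cc2cnc(Nc3ccc4[nH]ccc4c3)nc21` gives 100 nM and compound 3 `Cn1c(=O)c(S(=O)(=O)c2ccc(O)cc2)cc2cnc(Nc3ccc4[nH]ccc4c3)nc21` gives 100 nM. Compound 3 therefore stands level with compound 2, and both lie far under compound 1. The untested compound 4 `Cn1c(=O)c(S(=O)(=O)Nc2ccc(F)cc2)cc2cnc(Nc3ccc4[nH]ccc4c3)nc21` carries (4-fluorophenyl)amino in place of 4-hydroxyphenyl on a sulfonyl sulfur. Changes at this same place have mattered a great deal, as a 300-fold lower number from compound 1 to compound 3 (2.48 log units; beyond the scatter) and a 300-fold lower number from compound 1 to compound 2 (2.48 log units; beyond the scatter) were both large. By contrast, no change at the digits printed from compound 2 to compound 3 (within the scatter) stayed within the scatter. Within the data shown here, the entering group looks more like the 4-fluorobenzyl of compound 1, at 30000 nM, than like the 4-hydroxyphenyl of compound 3, although no tested compound carries it. A clearly weaker inhibitor is therefore expected, with an estimated 30-fold higher number from compound 3 to compound 4 (1.48 log units; beyond the scatter). Compound 4 is expected at about 3000 nM, within an estimated range from 300 nM to 30000 nM.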

Compound 4, half-maximal inhibitory concentration: 5000 nM
The estimate for compound 4 lay 1.7-fold (0.22 log units) below the measured number; the measured number falls inside the stated range.
By their numbers in this assay, from the lowest: compounds 2 and 3 (each within the scatter of the next); then compound 4; then compound 1.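

In this assay the (4-fluorophenyl)amino group gives up most of the strength seen with an aromatic ring held directly on the sulfonyl sulfur, with a 50-fold higher number from compound 3 to compound 4 (1.70 log units; beyond the scatter) and a 50-fold higher number from compound 2 to compound 4 (1.70 log units; beyond the scatter) as the two large steps. Compound 4 is still not as weak as compound 1, and a 6.0-fold lower number from compound 1 to compound 4 (0.78 log units; beyond the scatter) is a modest step, so the atom joining sulfur to ring, nitrogen here and carbon in the 4-fluorobenzyl, also changes the number. Among these four compounds, both groups with such a joining atom give clearly higher numbers than the two with the ring held directly on the sulfur, and none goes against this.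

Open, as far as these compounds go, is whether 4-fluorophenyl held directly on the sulfur would match compound 2 and compound 3, and where a plain methyl or an unsubstituted amino group on the sulfur would fall. Nothing given here explains why these steps take the sizes they do.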